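A few compounds are considered here, and "the series" means these few. Any claim that something is new, unique, unknown or untested is made for them only; others in the source may bear on it.

Measured compounds in a functional assay on KM12 cells (Homo sapiens) for cytotoxicity, read by sulforhodamine B assay, with a stated time of 48 h, tested at 10 uM; on this read-out lower numbers stand for a stronger effect and higher numbers for a weaker effect at the one concentration tested:
- compound 1 `COc1cc(-c2cc(/C=C/C(=O)c3ccc(N)cc3)[nH]n2)cc(OC)c1OC`: -67%
- compound 2 `COc1ccc(-c2cc(/C=C/C(=O)c3ccc(OC)c(OC)c3)[nH]n2)cc1`: -72%
- compound 3 `COc1cc(-c2cc(/C=C/C(=O)c3ccc(Cl)c(Cl)c3)[nH]n2)cc(OC)c1OC`: 19%

Compound 1 stands second highest of the three numbers; compound 2 lies within the scatter of it, compound 3 lies beyond the scatter above it. Within the data shown here, the only one-place step measured, a number 86 percentage points higher from compound 1 to compound 3 (beyond the scatter), concerns the group on the carbonyl carbon and so does not bear on the present change. Compound 4 `COc1ccc(-c2cc(/C=C/C(=O)c3ccc(N)cc3)[nH]n2)cc1OC` differs from compound 1 by hydrogen in place of methoxy on an aromatic carbon. Among the measured compounds shown here, no measured step addresses this ring; compound 2, which carries fewer methoxy groups on that side while differing elsewhere too, shows a value within the scatter of compound 1. A step of no more than the scatter is therefore expected, a number 7 percentage points higher from compound 1 to compound 4 (within the scatter). For compound 4 the estimate in this assay is -60%, ranging from -90% to -15%.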

Compound 4, a percentage reported as activity, at one concentration (the size of the read-out at that concentration, not a potency): -79%
Estimate against measurement, compound 4: 19 percentage points above, within the range that was stated.
By their numbers in this assay, from the lowest: compounds 4, 2 and 1 (each within the scatter of the next, the first and the last beyond it); then compound 3.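

Hydrogen in place of methoxy gives a number 12 percentage points lower from compound 1 to compound 4 (beyond the scatter) in this assay, the first direct reading on this position. The methoxy group that leaves is therefore not required for the effect at the one concentration tested, and its loss strengthens the effect modestly in this pair. Nothing measured accounts for the step.

On these data alone, whether a hydroxy group or an amine on this aromatic carbon would read like hydrogen or like methoxy stays open. So does whether the same change would hold with 3,4-dichlorophenyl on the carbonyl carbon.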